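The compounds below may be only part of what the source reports. "The series", "measured", "known", "first", "only" and "open" are said of these compounds alone.

The account opens with compound 2 `CCCCSc1nc(N)c2nc(O)n(Cc3ccccc3)c2n1`, which stands with the lowest of the two numbers recorded in a functional assay (spleen, spleen) for activation, with Mus musculus as the target (a lower number here means that less compound is needed, a higher number that more compound is needed for the effect), where compound 2 gives 0.01 uM. Its nearest neighbour in value is compound 3 `COc1ccc(Cn2c(O)nc3c(N)ncnc32)cc1`, which in this assay gives 10 uM, a gap far beyond the scatter. Compound 1 `Nc1ncnc2c1nc(Cl)n2Cc1ccccc1` is reported in this assay only as a limit, > 10 uM, and that limit is the limit of > 10 uM in this assay, at which 1 of the 3 values shown sits.

The step under study leads from compound 2 to compound 4 `COc1nc(N)c2nc(O)n(Cc3ccccc3)c2n1`, which has not yet been measured in this assay. The change is a single one, (methoxy in place of butylsulfanyl on an aromatic carbon). Among the measured compounds shown here, no measured pair in this set isolates that exchange, so the size of the step cannot be read from the data; the only hint is that compound 3, which carries no such group on its core, gives 10 uM. On that basis compound 4 is expected to give a higher number than compound 2, a step of a 100-fold higher number from compound 2 to compound 4 (2.00 log units; beyond the scatter). The estimate for compound 4 in this assay is 1 uM, with a range from 0.1 uM to 10 uM.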

Compound 4, minimum effective concentration: 0.1 uM
Beside the measured number, compound 4's estimate is 10-fold (1.00 log units) above it; low and high end bracket the measured number.
By their numbers in this assay, from the lowest: compound 2; then compound 4; then compound 3.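

In this assay, the exchange of butylsulfanyl for methoxy on the aromatic carbon between two ring nitrogen atoms gives a 10-fold higher number from compound 2 to compound 4 (1.00 log units; beyond the scatter) on the shared core, which shows that the number responds to the group held at this position. The step is modest, and compound 4 gives 0.1 uM with only methoxy in place, so the butylsulfanyl chain is not needed for the effect to appear at a low concentration. Nothing shown here gives a cause for this step.

As far as these compounds go, what remains open is whether the step follows the length of the chain or the atom linking it to the core: a butoxy group or a methylsulfanyl group at this place would separate the two. From the compounds shown here alone, how an amine at this position would stand also remains unknown.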